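Swapping chloro for methyl on a cytotoxic compound

The source may hold more compounds than are shown below. What is called first, only, known or untested is meant among the compounds shown, and "the series" means these compounds.

Compound 1 `Cc1ccc2c(c1)CCCN2c1nc(C)nc2ccccc12` gives 204 nM
Compound 2 `Cc1nc(N2CCCc3cc(Br)ccc32)c2ccccc2n1` gives 178 nM
Compound 3 `COc1ccc2c(c1)C(=O)CCN2c1nc(Cl)nc2ccccc12` gives 28 nM

All three numbers come from a functional assay on KB cells (Homo sapiens) for cytotoxicity, read by sulforhodamine B assay (a lower number here means a stronger inhibitor of growth, a higher number a weaker inhibitor of growth), and compound 3 stands lowest among them. Its value of 28 nM lies beyond the scatter from both of the others. The next structure, compound 4 `COc1ccc2c(c1)C(=O)CCN2c1nc(C)nc2ccccc12`, has methyl in place of chloro on an aromatic carbon between two ring nitrogen atoms, a change counted as methyl in place of chloro on an aromatic carbon in full. Within the data shown here, only one measured step links two compounds through a single change, a 1.1-fold lower number from compound 1 to compound 2 (0.06 log units; within the scatter) within the scatter, and it concerns bromo in place of methyl at a different place. That step therefore offers only weak guidance here. Compounds 1 and 2 carry the same methyl and have higher numbers, but they also differ from compound 3 elsewhere, so their gap cannot be assigned to this change. A slightly higher number is expected, with no step beyond the scatter, and the estimated step is a 1.6-fold higher number from compound 3 to compound 4 (0.21 log units; within the scatter) in this assay. For compound 4 the estimated value is 45 nM with an expected range from 12 nM to 170 nM in this assay.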

Compound 4, concentration for 50% growth inhibition: 19 nM
Compound 4: the middle estimate sits 2.4-fold (0.37 log units) above what was measured; the range from low to high includes it.
By their numbers in this assay, from the lowest: compounds 4 and 3 (each within the scatter of the next); then compounds 2 and 1 (each within the scatter of the next).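

In this assay, methyl in place of chloro on an aromatic carbon between two ring nitrogen atoms gives a 1.5-fold lower number from compound 3 to compound 4 (0.17 log units; within the scatter), so on this core the two groups cannot be told apart. Among these compounds, this is the first reading of this position, since the only earlier single-change step concerned bromo in place of methyl at a different place. Nothing available explains why the two groups read alike.

The compounds shown leave open how an amine, a nitrile or a longer chain would read on this same aromatic carbon, where so far only chloro and methyl can be compared directly. On these data alone, it also remains open whether the same swap would stay within the scatter on the core of compound 1, for which only methyl appears here.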